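Methoxy for hydrogen on the core of compound 3

This account rests on a few compounds, and the source may have more. Where it says the series, first, only, none or still open, it means among the compounds named here.

Measured in a functional assay on cells (Cancer cell lines, Homo sapiens) for cytotoxicity, with a stated time of 48 h; on this read-out higher numbers stand for weaker inhibition of growth and lower numbers for stronger inhibition of growth:
compound 1, `COc1cc2c(/C=C3/C(=O)Nc4ccc(O)cc43)c(Cl)n(Cc3cc(OC)c(OC)c(OC)c3)c2cc1C`, gives 2340 nM
compound 2, `O=C1/C(=C/c2c(Cl)[nH]c3ccccc23)c2ccccc2N1Cc1ccccc1`, gives 9120 nM
compound 3, `COc1c(/C=C2/C(=O)Nc3ccccc32)c2ccccc2n1-c1ccccc1`, gives 1380 nM

Three compounds share a related core and were measured in this assay. Compound 3 and compound 1 lie within the scatter of each other, so no order can be read between them. Compound 2 gives a number that stands beyond the scatter of compound 3. Going by the values given here, no two of the measured compounds differ in only one place, so no single step has been measured here.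

Compound 4, `COc1ccc2c(c1)/C(=C\c1c(OC)n(-c3ccccc3)c3ccccc13)C(=O)N2`, has not yet been measured. It differs from compound 3 in one place: methoxy in place of hydrogen on an aromatic carbon, on an aromatic carbon of a six-membered aromatic ring of carbon only, part of a fused or bridged system of two rings. Among the compounds with values here, the data give no measured step of this kind, so the size of the change can only be guessed from the spread of the three numbers. Compound 4 is expected to stay close to compound 3, with an estimated step of a 1.1-fold higher number from compound 3 to compound 4 (0.04 log units; within the scatter) not beyond the scatter in either direction. Compound 4 is therefore estimated at 1500 nM in this assay, with an expected range from 600 nM to 4000 nM.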

Compound 4, concentration for 50% growth inhibition: 2000 nM
The estimate for compound 4 lay 1.3-fold (0.12 log units) below the measured number; the measured number falls inside the stated range.
By their numbers in this assay, from the lowest: compounds 3, 4 and 1 (each within the scatter of the next); then compound 2.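

In this assay, the replacement of hydrogen by methoxy gives the first single step among these compounds, a 1.4-fold higher number from compound 3 to compound 4 (0.16 log units; within the scatter), which the earlier compounds, all differing in more than one place, could not provide. This step lies within the scatter, so on this aromatic carbon of the six-membered ring of carbon only, meta to a fused ring and para to a fused ring, the methoxy group brings no change that this read-out can distinguish from repeated measurement of the same compound. No supporting measurement bears on why the number stays within the scatter, so the result describes only the size of the step.

The compounds shown leave open whether a different group on this same aromatic carbon, such as an amine or a carboxylic acid, would give a step beyond the scatter. They also leave open whether methoxy in place of hydrogen would stay within the scatter at this carbon on the other cores shown, since this single step comes from the core of compound 3 alone.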